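Fluoro in Place of Trifluoromethyl: What Compound 4 May Give

This account rests on a few compounds, and the source may have more. Where it says the series, first, only, none or still open, it means among the compounds named here.

Measured so far:
compound 1 `C=CCn1c(=O)/c(=C\c2cccc(F)c2)[nH]c(=O)/c1=C\c1ccccc1OC` gives 8890 nM in a functional assay on HL-60 cells (Homo sapiens) for cytotoxicity, read by CCK-8 assay, with a stated time of 72 h; on this read-out lower numbers stand for stronger inhibition and higher numbers for weaker inhibition
compound 2 `C=CCn1c(=O)/c(=C\c2cccc(Br)c2)[nH]c(=O)/c1=C\c1ccccc1OC` gives 5200 nM
compound 3 `C=CCn1c(=O)/c(=C\c2ccccc2C(F)(F)F)[nH]c(=O)/c1=C\c1ccccc1OC` gives 4600 nM

Compound 3 has the lowest of the three numbers, yet the steps leading to it, a 1.1-fold lower number from compound 2 to compound 3 (0.05 log units; within the scatter) and a 1.9-fold lower number from compound 1 to compound 3 (0.29 log units; within the scatter), both lie within the scatter, so none of the three can be set apart. Compound 4 `C=CCn1c(=O)/c(=C\c2ccccc2F)[nH]c(=O)/c1=C\c1ccccc1OC` differs from compound 3 by fluoro in place of trifluoromethyl on an aromatic carbon. Going by the values given here, the steps that bear on this are all halogen or trifluoromethyl exchanges on the same side of the shared core: a 1.7-fold lower number from compound 1 to compound 2 (0.23 log units; within the scatter), a 1.9-fold lower number from compound 1 to compound 3 (0.29 log units; within the scatter) and a 1.1-fold lower number from compound 2 to compound 3 (0.05 log units; within the scatter), each within the scatter. No step beyond the scatter is therefore expected for compound 4, and its value is estimated at 5500 nM, between 2500 nM and 12000 nM, which means an expected step of a 1.2-fold higher number from compound 3 to compound 4 (0.08 log units; within the scatter).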

Compound 4, half-maximal inhibitory concentration: 18500 nM
Compound 4: middle estimate off by 3.4-fold (0.53 log units), on the low side; the measured number lies above the stated range.
By their numbers in this assay, from the lowest: compounds 3, 2 and 1 (each within the scatter of the next); then compound 4.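

In this assay, going by these compounds alone, the aromatic carbon carrying trifluoromethyl proves sensitive to this exchange: fluoro there gives a 4.0-fold higher number from compound 3 to compound 4 (0.60 log units; beyond the scatter) and so the first step beyond the scatter. The 2-fluorophenyl group also separates from the earlier aryl groups, with a 3.6-fold higher number from compound 2 to compound 4 (0.55 log units; beyond the scatter) and a 2.1-fold higher number from compound 1 to compound 4 (0.32 log units; beyond the scatter) as its steps, although those earlier compounds could not be set apart from one another. Nothing measured here explains the change. The compounds shown leave open how chloro, a nitrile or an amine on this same aromatic carbon would compare.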